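The compounds below may be only part of what the source reports. "The series", "measured", "known", "first", "only" and "open" are said of these compounds alone.

Measured compounds in a functional assay on PC-3 cells (Homo sapiens) for cytotoxicity, read by MTT assay, with a stated time of 72 h; a higher number here means a weaker inhibitor, a lower number a stronger inhibitor:
compound 1, `N=C(Nc1cccc(C(F)(F)F)c1)c1cc2c(-c3ccccc3)n[nH]c2cn1`, 19900 nM
compound 2, `Cn1nc(-c2ccccc2)c2cc(C(=N)Nc3cccc(C(F)(F)F)c3)ncc21`, 20900 nM
compound 3, `N=C(Nc1ccccc1)c1cc2c(-c3ccccc3)n[nH]c2cn1`, 23000 nM

Compound 1 stands apart from neither neighbour: the step of a 1.1-fold higher number from compound 1 to compound 2 (0.02 log units; within the scatter) and the step of a 1.2-fold higher number from compound 1 to compound 3 (0.06 log units; within the scatter) both leave the numbers inside the usual scatter, so the three measured compounds are indistinguishable on this assay.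

Compound 4, `N=C(Nc1cccc(C(F)(F)F)c1)c1cc2c(-c3ccccc3)n[nH]c2c(NC2CCCCC2)n1`, differs from compound 1 by cyclohexylamino in place of hydrogen on an aromatic carbon. Neither measured step touches this position: the step to compound 2 changes an aromatic nitrogen, the step to compound 3 changes a substituent on the pendant aryl ring, and both were flat. Within the data shown here, no measured step therefore bears directly on the new change, and the series so far shows only that small peripheral edits leave the number unchanged. A cyclohexylamino is a larger addition than either of those edits, so a somewhat wider outcome is allowed for, but the expected step of a 1.4-fold lower number from compound 1 to compound 4 (0.15 log units; within the scatter) is taken as small and the direction uncertain. Compound 4 is estimated at 14000 nM, in the range 4000 nM to 45000 nM.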

Compound 4, half-maximal inhibitory concentration: 25000 nM
Beside the measured number, compound 4's estimate is 1.8-fold (0.25 log units) below it; measured number inside the range.
By their numbers in this assay, from the lowest: compounds 1, 2, 3 and 4 (each within the scatter of the next).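

In this assay, the aromatic carbon next to the ring nitrogen takes cyclohexylamino in place of hydrogen with no readable change in the number (a 1.3-fold higher number from compound 1 to compound 4 (0.10 log units; within the scatter)). The earlier steps shown here touched only an aromatic nitrogen and a substituent on the pendant aryl ring, whereas this one shows that a much larger group, added directly to the shared core, also leaves the number within the scatter. Nothing available explains why this position stays flat.

All four compounds remain within the scatter of their neighbours in the ordering, so no change shown yet moves the number in either direction. As far as these compounds go, whether this carbon responds to anything else stays open: a carboxylic acid, a morpholine or a short chain ending in a primary amine would test it.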